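Inverting three stereocentres of compound 3

The source may hold more compounds than are shown below. What is called first, only, known or untested is meant among the compounds shown, and "the series" means these compounds.

Compound 1 `O=C(O)[C@H]1NCC=C[C@@H]1O` gives 25% in an assay for inhibition of alpha-N-acetylgalactosaminidase (Gallus gallus), tested at 1000 uM; a lower number here means less inhibition, a higher number more inhibition at the concentration tested (going by the name of the read-out). Compound 2 `O=C(O)[C@H]1NC[C@H](O)[C@H](O)[C@H]1O` gives 21%, and compound 3 `O=C(O)[C@H]1NC[C@H](O)[C@@H](O)[C@H]1O` gives 31%, which is the highest of the three numbers, though its gaps to compound 1 and compound 2 both lie within the scatter. Going by the values given here, the only measured step that bears on a change of configuration is a number 10 percentage points higher from compound 2 to compound 3 (within the scatter), a small effect that rests on (the fact that compounds 2 and 3 differ only in the configuration as drawn). Compound 4 `O=C(O)[C@@H]1NC[C@@H](O)[C@@H](O)[C@@H]1O` differs from compound 3 in this way: the two compounds have the same atoms and bonds and differ only in configuration as drawn: 3 of 4 stereo elements differ; a stereocentre at a saturated ring carbon is drawn S in compound 3 and R in compound 4; a stereocentre at a saturated ring carbon is drawn S in compound 3 and R in compound 4; a stereocentre at a saturated ring carbon is drawn S in compound 3 and R in compound 4. With three centres inverted rather than one, the measured step is an imperfect guide, so no shift beyond the scatter is expected in this assay, with a broad range. Compound 4 is estimated at 24% (range 5% to 50%), an expected step of a number 7 percentage points lower from compound 3 to compound 4 (within the scatter).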

Compound 4, a percentage reported as inhibition, at one concentration (the size of the read-out at that concentration, not a potency): 7.2%
Beside the measured number, compound 4's estimate is 16.8 percentage points above it; the measured number falls inside the stated range.
By their numbers in this assay, from the lowest: compound 4; then compounds 2, 1 and 3 (each within the scatter of the next).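

In this assay, the step is a number 23.8 percentage points lower from compound 3 to compound 4 (beyond the scatter), and the mirror-image pair gives a number 13.8 percentage points lower from compound 2 to compound 4 (beyond the scatter), whereas the earlier single inversion stayed within the scatter. These modest steps are the first beyond the scatter among these compounds, and no atom enters or leaves, so configuration alone accounts for them: the fact that compounds 3 and 4 differ only in the configuration as drawn

On these data alone, compound 4 inverts three centres together, and which of them carries the drop stays open. Also open, as far as these compounds go, is whether an amide in place of the carboxylic acid would show the same dependence on configuration.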